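Swapping the aryl group on a triazole-linked diol ether

The source may hold more compounds than are shown below. What is called first, only, known or untested is meant among the compounds shown, and "the series" means these compounds.

Compound 2 `O=C1COc2ccc(-n3cc(C[C@H](O)COCCOC[C@@H](O)Cc4ccc(-c5ccccc5)cc4)nn3)cc2N1`: 42500 nM
Compound 1 `COC1=C(OC)C(=O)C(CCCCCCCCCCn2cc(C[C@H](O)COCCOC[C@@H](O)Cc3ccc(-c4ccccc4)cc3)nn2)=C(C)C1=O`: 600 nM

In a functional assay on HCT-116 cells (Homo sapiens) for inhibition, read by MTT assay, with a stated time of 72 h (a lower number here means a stronger inhibitor of growth, a higher number a weaker inhibitor of growth), compound 2 gives 42500 nM, the highest number of the two; compound 1 gives 600 nM, a far lower number, beyond the scatter. Compound 3 `O[C@H](COCCOC[C@@H](O)Cc1cn(-c2cccnc2)nn1)Cc1ccc(-c2ccccc2)cc1` keeps the shared core of compound 2 and differs in one place: a group of 6 heavy atoms (5 carbon, 1 nitrogen; one six-membered aromatic ring with 1 hetero atom) in place of a group of 11 heavy atoms (8 carbon, 1 nitrogen, 2 oxygen; one six-membered non-aromatic ring with 2 hetero atoms, one six-membered aromatic ring of carbon only), on an aromatic nitrogen. Going by the values given here, no measured step mirrors this change, so the size of the step from compound 2 to compound 3 in this assay is uncertain; a move of no more than the scatter, in either direction, is expected. Compound 3 is therefore estimated at 50000 nM, within 15000 nM to 160000 nM, an expected step of a 1.2-fold higher number from compound 2 to compound 3 (0.07 log units; within the scatter).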

Compound 3, concentration for 50% growth inhibition: 46800 nM
Compound 3: the middle estimate sits 1.1-fold (0.03 log units) above what was measured, within the range that was stated.
By their numbers in this assay, from the lowest: compound 1; then compounds 2 and 3 (each within the scatter of the next).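

Putting pyridin-3-yl in place of the larger group with its non-aromatic ring, on the aromatic nitrogen of the five-membered ring, gives in this assay a 1.1-fold higher number from compound 2 to compound 3 (0.04 log units; within the scatter) and so no real shift. At this position, the smaller group and the loss of the hydrogen-bond donor therefore make no difference beyond the scatter between these two aromatic groups. No measurement given here offers a reason for this result.

On these data alone, whether a plain phenyl, an aminophenyl or a benzoic acid group on this nitrogen would move the number remains open.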